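Working notes: from compound 2 to compound 4

The source may report more compounds than this note shows. Statements on the series, on what has been measured and on what is new or still open speak of the compounds shown alone.

Compound 1 `CCOC(=O)c1cccc(-c2ccc(OCC)cc2)c1`: 50000 nM
Compound 2 `CCOC(=O)c1cccc(-c2ccc(N(C)C)cc2)c1`: 40000 nM
Compound 3 `CCOC(=O)c1cccc(-c2ccc(CN3CCCC3)cc2)c1`: > 200000 nM, a limit

In an assay on COS-7 cells for inhibition of patatin-like phospholipase domain-containing protein 2 (Mus musculus) (on this read-out lower numbers stand for stronger inhibition and higher numbers for weaker inhibition), compound 2 gives 40000 nM and compound 1 gives 50000 nM; the step is a 1.3-fold lower number from compound 1 to compound 2 (0.10 log units; within the scatter). For compound 3 the assay reports only a limit, (the limit of > 200000 nM in this assay, at which 1 of the 3 values shown sits). Compound 2 thus stands at the lowest of the two numbers, with compound 1 within the scatter of it. The remaining steps, an at least 4.0-fold higher number from compound 1 to compound 3 (0.60 log units; beyond the scatter) and an at least 5.0-fold higher number from compound 2 to compound 3 (0.69 log units; beyond the scatter), both concern the group on the other ring.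

Compound 4 `CN(C)c1ccc(-c2cccc(NC(=O)C(C)(C)C)c2)cc1` differs from compound 2 by ((tert-butyl)carbonyl)amino in place of ethoxycarbonyl on an aromatic carbon. Among the measured compounds shown here, no measured step changes this position, so nothing measured bears on it directly, and the expected step is no change at the digits printed from compound 2 to compound 4 (within the scatter), none beyond the scatter. Compound 4 is therefore estimated at 40000 nM, between 8000 nM and 200000 nM.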

Compound 4, half-maximal inhibitory concentration: > 200000 nM
Compound 4 was reported as a limit; the forecaster's own chance of this, stated with the estimate: 30%; at least 5.0-fold (0.69 log units) between middle value and limit.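

Among the compounds shown here, this is the first measured change at the ethoxycarbonyl position: in this assay, ((tert-butyl)carbonyl)amino in its place gives an at least 5.0-fold higher number from compound 2 to compound 4 (0.69 log units; beyond the scatter). The earlier steps shown here changed only the group on the other ring, so this position also responds to substitution. Compound 4 is reported only as a limit, so the step gives a minimum and not a true size: the limit of > 200000 nM in this assay, at which 2 of the 4 values shown sit.

The compounds shown do not separate the loss of ethoxycarbonyl from the entry of ((tert-butyl)carbonyl)amino. Going by these compounds, how a carboxylic acid or an acetylamino group at this position compares with compound 2 also stays open.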